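Removing the Methyl from the Methoxy Group of Compound 2

This account rests on a few compounds, and the source may have more. Where it says the series, first, only, none or still open, it means among the compounds named here.

For the measured compounds named here, compound 2 `COc1cc(-c2nn(-c3cccc(NC(=O)Nc4cc(C(F)(F)F)cc(C(F)(F)F)c4)c3)cc2-c2ccncc2)ccc1Cl` gives the lowest of the three numbers measured so far in a functional assay on SK-MEL-5 cells (Homo sapiens) for inhibition, read by sulforhodamine B assay, with a stated time of 48 h (a lower number here means a stronger inhibitor of growth, a higher number a weaker inhibitor of growth), at 1360 nM. Its nearest neighbour is compound 3 `COc1cc(-c2nn(-c3cccc(NC(=O)Nc4cccc(C(F)(F)F)c4)c3)cc2-c2ccncc2)ccc1Cl`, which in this assay gives 1390 nM; the step of a 1.0-fold higher number from compound 2 to compound 3 (0.01 log units; within the scatter) lies within the scatter, so the two cannot be ordered. The furthest is compound 1 `O=C(Nc1cccc(-n2cc(-c3ccncc3)c(-c3ccc(Cl)c(O)c3)n2)c1)Nc1cccc(C(F)(F)F)c1`, which in this assay gives 4710 nM.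

Compound 4 `O=C(Nc1cccc(-n2cc(-c3ccncc3)c(-c3ccc(Cl)c(O)c3)n2)c1)Nc1cc(C(F)(F)F)cc(C(F)(F)F)c1` has not yet been measured. It differs from compound 2 in one place: hydrogen in place of methyl on an oxygen on an aromatic ring.

Going by the values given here, one measured step bears directly on this change, run in the opposite direction: a 3.4-fold lower number from compound 1 to compound 3 (0.53 log units; beyond the scatter). Since the step of a 1.0-fold higher number from compound 2 to compound 3 (0.01 log units; within the scatter) is within the scatter, the second trifluoromethyl on the outer ring is not expected to alter the outcome, and the methyl-to-hydrogen change is expected to read in compound 4 much as it did between compound 1 and compound 3, only reversed. A higher number of modest size is therefore expected, beyond the scatter.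

Compound 4 is estimated to give 4600 nM in this assay, with a range from 2000 nM to 10500 nM. The expected step of a 3.4-fold higher number from compound 2 to compound 4 (0.53 log units; beyond the scatter) mirrors the earlier step in reverse.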

Compound 4, concentration for total growth inhibition: 1250 nM
Compound 4: the middle estimate sits 3.7-fold (0.57 log units) above what was measured; the whole stated range lies above it.
By their numbers in this assay, from the lowest: compounds 4, 2 and 3 (each within the scatter of the next); then compound 1.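

With the two trifluoromethyl groups on the outer ring, the change from methoxy to hydroxy in the 4-chloro-3-methoxyphenyl group gives no readable shift in this assay, at a 1.1-fold lower number from compound 2 to compound 4 (0.04 log units; within the scatter), so this change does not read the same on the two cores: the same change on two cores in this assay, a 3.4-fold lower number (0.53 log units; beyond the scatter) from compound 1 to compound 3 and a 1.1-fold higher number (0.04 log units; within the scatter) from compound 4 to compound 2, 3.7-fold (0.57 log units) apart, beyond the scatter of two such steps

The second trifluoromethyl, which made no readable difference among the methoxy compounds, does make one among the hydroxy compounds, at a 3.8-fold lower number from compound 1 to compound 4 (0.58 log units; beyond the scatter), so its effect too depends on the group at the oxygen: the same change on two cores in this assay, a 1.0-fold higher number (0.01 log units; within the scatter) from compound 2 to compound 3 and a 3.8-fold higher number (0.58 log units; beyond the scatter) from compound 4 to compound 1, 3.7-fold (0.57 log units) apart, beyond the scatter of two such steps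

The higher number of compound 1 therefore goes with the pairing of a hydroxy and a lone trifluoromethyl, and compound 4 goes against any reading of the hydroxy as a loss in itself.

These four compounds form one square of changes in one cell line, and they do not show why the two changes depend on each other. They also leave open whether the same dependence holds with an ethyl group on the oxygen or an amine in place of the hydroxy, and whether a chlorine could stand in for the second trifluoromethyl.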